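Adding tert-butyl to a small bromo compound

The compounds below may be only part of what the source reports. "The series", "measured", "known", "first", "only" and "open" are said of these compounds alone.

In an ADME assay on cells (Peritoneal macrophage, Mus musculus, strain Swiss) for cytotoxicity, with a stated time of 24 h (on this read-out higher numbers stand for lower toxicity in this test and lower numbers for higher toxicity in this test), compound 1 `O=C1C(Br)=CC(=O)c2c(I)cccc21` gives a reading (12200 nM) and compound 2 `O=C1C=CC(=O)C(Br)=C1` gives a reading (34400 nM) that is the higher of the two actual numbers, with a gap between them that lies beyond the usual scatter. Compound 3 `O=C1C=C([Se]c2ccccc2)C(=O)C=C1[Se]c1ccccc1` gives > 100000 nM as its reading, which is a limit and not a number.

Compound 4 `CC(C)(C)C1=CC(=O)C(Br)=CC1=O` has not yet been measured. It differs from compound 2 by tert-butyl in place of hydrogen on a double-bonded ring carbon in one place, with tert-butyl in place of hydrogen on a double-bonded ring carbon. Among the measured compounds shown here, no measured pair of compounds shows this change, so the expectation is a loose one and starts from the reading of compound 2 (34400 nM) alone. In this assay no step beyond the scatter is expected, and the estimated step of a 1.2-fold higher number from compound 2 to compound 4 (0.09 log units; within the scatter) leans only slightly towards a higher number. For compound 4 the expected value is 42000 nM on an estimated range from 14000 nM to 100000 nM as a rough guide.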

Compound 4, concentration lethal to 50% of the cells: 42300 nM
Compound 4: middle estimate off by 1.0-fold (0.00 log units), on the low side; the range from low to high includes it.
By their numbers in this assay, from the lowest: compound 1; then compounds 2 and 4 (each within the scatter of the next). At a limit, above all of these: compound 3.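

In this assay, tert-butyl in place of hydrogen on a double-bonded ring carbon gives a 1.2-fold higher number from compound 2 to compound 4 (0.09 log units; within the scatter). Among the compounds shown here, this is the first direct view of this position, and it shows that the readings with hydrogen and with tert-butyl there cannot be told apart in this test. Compound 2 and compound 4 both give actual numbers, so the size of this step can be read directly, clear of the limit of the test: the limit of > 100000 nM in this assay, at which 1 of the 4 values shown sits.

From the compounds shown here alone, whether a methyl group, an amine or a carboxylic acid at this same ring carbon would also leave the reading within the scatter remains open. This single pair also cannot show whether tert-butyl would behave the same way on the core of compound 1.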